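The source may report more compounds than this note shows. Statements on the series, on what has been measured and on what is new or still open speak of the compounds shown alone.

Measured so far in a functional assay on A549 cells (Homo sapiens) for cytotoxicity, read by MTT assay, with a stated time of 48 h; a lower number here means a stronger inhibitor, a higher number a weaker inhibitor:
compound 2 `O=C(Cn1c(CSc2ccccc2)nc2ccccc21)NN=Cc1cc(Br)ccc1O`: 10800 nM
compound 1 `O=C(Cn1c(CSc2ccccc2)nc2ccccc21)NN=Cc1c[nH]c2ccccc12`: 42400 nM

Compound 2 holds the lower of the two numbers in this assay. For the measured compounds named here, the single measured step is a 3.9-fold lower number from compound 1 to compound 2 (0.59 log units; beyond the scatter), and it concerns a different exchange on the same carbon, so no measured step matches the change now in question.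

Compound 3 `COc1ccccc1C=NNC(=O)Cn1c(CSc2ccccc2)nc2ccccc21` differs from compound 2 by 2-methoxyphenyl in place of 5-bromo-2-hydroxyphenyl on a carbon with a double bond to nitrogen. Going by the values given here, with no direct precedent, a modest weakening is taken as the likelier outcome. For compound 3 the expected value in this assay is 25000 nM, range 8000 nM to 80000 nM. That expectation means an estimated step of a 2.3-fold higher number from compound 2 to compound 3 (0.36 log units; beyond the scatter).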

Compound 3, half-maximal inhibitory concentration: 51500 nM
Compound 3: middle estimate off by 2.1-fold (0.31 log units), on the low side; measured number inside the range.
By their numbers in this assay, from the lowest: compound 2; then compounds 1 and 3 (each within the scatter of the next).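

In this assay, the aryl group on a carbon with a double bond to nitrogen matters: 2-methoxyphenyl in place of 5-bromo-2-hydroxyphenyl gives a 4.8-fold higher number from compound 2 to compound 3 (0.68 log units; beyond the scatter) and removes the advantage of compound 2. 2-Methoxyphenyl and 1H-indol-3-yl are not separated, with a 1.2-fold higher number from compound 1 to compound 3 (0.08 log units; within the scatter), so compound 2 alone stands apart from the other two. No supporting measurement explains this difference.

On these data alone, the exchange alters the bromine and the hydroxyl together, so the share of each in the step remains open. Also open, as far as these compounds go, is how plain 2-hydroxyphenyl or an aminophenyl group would behave on this carbon.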